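The source may report more compounds than this note shows. Statements on the series, on what has been measured and on what is new or still open speak of the compounds shown alone.

Measured so far in an in vitro ADME assay on microsomes from liver (Homo sapiens) for pharmacokinetics, read by LC-MS, with a stated time of 10 min, tested at 1 uM; on this read-out higher numbers stand for fast clearance and lower numbers for slow clearance:
compound 1 `CN1C[C@H](C(=O)Nc2ccccc2)[C@@H](c2ccc(/C=C/C(=O)Nc3ccccc3N)cc2)C1` gives 7 mL/min/kg
compound 2 `Cc1ccc(NC(=O)[C@H]2CN(C)C[C@@H]2c2ccc(/C=C/C(=O)Nc3ccccc3N)cc2)cc1` gives 15 mL/min/kg
compound 3 `CN1C[C@H](C(=O)Nc2cccnc2)[C@@H](c2ccc(/C=C/C(=O)Nc3ccccc3N)cc2)C1` gives 10 mL/min/kg

Compound 2 differs from compound 1 by methyl in place of hydrogen on an aromatic carbon, and this gives a 2.1-fold higher number from compound 1 to compound 2 (0.33 log units; beyond the scatter). The two cores of the pair under review differ by pyridin-3-yl in place of phenyl on an amide-type nitrogen, a step of a 1.4-fold higher number from compound 1 to compound 3 (0.15 log units; within the scatter); between compound 2 and compound 3 the step is a 1.5-fold lower number from compound 2 to compound 3 (0.18 log units; within the scatter), so no order among compounds 1, 2 and 3 beyond the methyl step is claimed.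

Compound 4 `Cc1ccc(NC(=O)[C@H]2CN(C)C[C@@H]2c2ccc(/C=C/C(=O)Nc3ccccc3N)cc2)cn1` is not yet measured in this assay. It differs from compound 3 by methyl in place of hydrogen on an aromatic carbon. This is the same kind of change as that from compound 1 to compound 2, but the place differs: in compound 4 the methyl sits on an aromatic carbon of a six-membered aromatic ring with 1 nitrogen, next to the ring nitrogen, whereas in compound 2 the ring is of carbon only. For the measured compounds named here, for compound 4 a step of a 1.9-fold higher number from compound 3 to compound 4 (0.28 log units; within the scatter) is expected, resting on the single earlier example a 2.1-fold higher number from compound 1 to compound 2 (0.33 log units; beyond the scatter). Compound 4 is accordingly estimated at 19 mL/min/kg, with a range of 10 mL/min/kg to 36 mL/min/kg in this assay.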

Compound 4, clearance: 8 mL/min/kg
Beside the measured number, compound 4's estimate is 2.4-fold (0.38 log units) above it, outside the stated range (below it).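

In this assay the methyl step does not carry over unchanged from one core to the other: the same change on two cores in this assay, a 2.1-fold higher number (0.33 log units; beyond the scatter) from compound 1 to compound 2 and a 1.3-fold lower number (0.10 log units; within the scatter) from compound 3 to compound 4, 2.7-fold (0.43 log units) apart, beyond the scatter of two such steps. With the methyl on an aromatic carbon next to the ring nitrogen, as 6-methylpyridin-3-yl, the result is a 1.3-fold lower number from compound 3 to compound 4 (0.10 log units; within the scatter), and the other two new steps, a 1.1-fold higher number from compound 1 to compound 4 (0.06 log units; within the scatter) and a 1.9-fold lower number from compound 2 to compound 4 (0.27 log units; within the scatter), also lie within the scatter, so no order is claimed between compound 4 and compounds 1, 2 or 3. This rests on a single pair for each core and does not show why the two steps part, as the ring nitrogen and the setting of the methyl change together in these compounds.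

The compounds shown leave open whether a fluoro, a methoxy or an amine group in place of the methyl would give matching steps on the two cores. Also open, on these data alone, is whether a longer chain such as ethyl would follow the step seen on the core of compound 1 or the one seen on the core of compound 3.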